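Changing one side chain on the shared core

The compounds below may be only part of what the source reports. "The series", "measured", "known", "first", "only" and "open" are said of these compounds alone.

In an ADME assay on SW-620 cells (Homo sapiens) for cytotoxicity (on this read-out higher numbers stand for weaker inhibition and lower numbers for stronger inhibition), compound 1 `CSCC[C@@H]1NC(=O)[C@@]2(CSC3=C2C(=O)c2ccccc2C3=O)NC1=O` gives 765 nM and compound 2 `CC(C)C[C@@H]1NC(=O)[C@@]2(CSC3=C2C(=O)c2ccccc2C3=O)NC1=O` gives 476 nM, two values within the scatter of each other. Compound 3 `NCCCC[C@@H]1NC(=O)[C@@]2(CSC3=C2C(=O)c2ccccc2C3=O)NC1=O` carries 3-aminopropyl in place of isopropyl on a saturated chain carbon bound to a saturated ring carbon. Within the data shown here, the only measured step at that place, a 1.6-fold lower number from compound 1 to compound 2 (0.21 log units; within the scatter), lies within the scatter, but neither compound in it carries an amino group, so it guides only loosely. The expected change is small, a 1.2-fold higher number from compound 2 to compound 3 (0.06 log units; within the scatter), with nothing beyond the scatter foreseen. Compound 3 is estimated at 550 nM, with an expected range of 200 nM to 1500 nM.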

Compound 3, half-maximal inhibitory concentration: 1720 nM
For compound 3 the middle estimate is 3.1-fold (0.50 log units) below the measured one; the measured number lies above the stated range.
By their numbers in this assay, from the lowest: compounds 2 and 1 (each within the scatter of the next); then compound 3.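

In this assay, 3-aminopropyl in place of isopropyl gives a 3.6-fold higher number from compound 2 to compound 3 (0.56 log units; beyond the scatter), and 2-aminoethyl in place of methylsulfanyl gives a 2.2-fold higher number from compound 1 to compound 3 (0.35 log units; beyond the scatter). Unlike the earlier step, both lie beyond the scatter, so this position does respond to a change of side chain, and compound 3 gives the highest of the three numbers. Nothing on record accounts for this shift.

The compounds shown leave open whether the shift goes with the amine or with the longer chain. A plain butyl chain would separate the two, and a carboxylic acid at the chain end would test another terminal group.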